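Swapping an Ethyl for a Furan Ring on Compound 3

This account rests on a few compounds, and the source may have more. Where it says the series, first, only, none or still open, it means among the compounds named here.

Three related compounds have been tested in an assay on isolated protein for inhibition of NAD-dependent protein deacylase sirtuin-6 (Homo sapiens), read by fluorescence, tested at 200 uM; a lower number here means less inhibition, a higher number more inhibition at the concentration tested (going by the name of the read-out). Compound 1 `O=C(Nc1ccc(O)c(C(=O)O)c1)c1ccc(NC(=O)C2CC2)cc1` gives 50%, and compound 2 `O=C(Nc1ccc(C(=O)O)c(O)c1)c1cccc(N2C(=O)CCS2(=O)=O)c1` gives 44%. Compound 3 `CCC(=O)Nc1ccc(C(=O)Nc2ccc(C(=O)O)c(O)c2)cc1` gives 70%, the highest of the three numbers; its gap to compound 1 and its larger gap to compound 2 both lie beyond the usual scatter of such measurements. Compound 4 `O=C(Nc1ccc(C(=O)O)c(O)c1)c1ccc(NC(=O)c2ccco2)cc1` differs from compound 3 in one place: furan-2-yl in place of ethyl on a carbonyl carbon. For the measured compounds named here, no measured pair shows this exact change, so its effect on inhibition is open. Any shift is expected to stay within the scatter, in either direction. Compound 4 is estimated to give 65% in this assay, within a plausible range from 40% to 85%. The change is thus expected to amount to a number 5 percentage points lower from compound 3 to compound 4 (within the scatter).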

Compound 4, a percentage reported as inhibition, at one concentration (the size of the read-out at that concentration, not a potency): 100%
The estimate for compound 4 lay 35 percentage points below the measured number, outside the stated range (above it).
By their numbers in this assay, from the lowest: compounds 2 and 1 (each within the scatter of the next); then compound 3; then compound 4.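

On the carbonyl carbon bonded to the amide-type nitrogen, furan-2-yl in place of ethyl gives a number 30 percentage points higher from compound 3 to compound 4 (beyond the scatter) in this assay. For the compounds shown here, the earlier compounds offered no pair differing in one place, so this is the first direct sign that the group here can shift inhibition beyond the scatter. No supporting data explain this rise.

Going by these compounds, whether the ring or its oxygen matters stays open; a phenyl or thiophen-2-yl group on the same carbonyl carbon would help separate the two. This single step also cannot show whether the change would act similarly on another core.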